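Ethyl for Chloro on the Thiazole Side of the Core

The compounds below may be only part of what the source reports. "The series", "measured", "known", "first", "only" and "open" are said of these compounds alone.

Measured so far:
- compound 1, `CCOC(=O)C1=C(C)NC(C)=C(C(=O)OCC)C1c1c(-c2ccc([N+](=O)[O-])cc2)nc2sc(Cl)cn12`: 2170 nM
- compound 2, `CCOC(=O)C1=C(C)NC(C)=C(C(=O)OCC)C1c1c(-c2cc([N+](=O)[O-])c(Cl)cc2Cl)nc2sc(Cl)cn12`: 220 nM

In an ADME assay on Right cardiac atrium (Cavia porcellus) (a lower number here means that less compound is needed, a higher number that more compound is needed for the effect), compound 1 gives 2170 nM and compound 2 gives 220 nM. Among the compounds with values here, compound 2 therefore holds the lowest of the two numbers so far, with compound 1 as its only neighbour, reached by a 9.9-fold lower number from compound 1 to compound 2 (0.99 log units; beyond the scatter), brought about by 2,4-dichloro-5-nitrophenyl in place of 4-nitrophenyl on an aromatic carbon.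

Compound 3, `CCOC(=O)C1=C(C)NC(C)=C(C(=O)OCC)C1c1c(-c2cc([N+](=O)[O-])c(Cl)cc2Cl)nc2sc(CC)cn12`, keeps everything of compound 2 and differs only by ethyl in place of chloro on an aromatic carbon. Within the data shown here, no measured step touches this part of the shared core: the single step seen, from compound 1 to compound 2, changed the phenyl ring and not the five-membered ring with nitrogen and sulfur. Nothing in the data therefore points to a particular direction, so the expected step from compound 2 to compound 3 is no change at the digits printed from compound 2 to compound 3 (within the scatter), and the uncertainty is wider than the usual scatter. Compound 3 is estimated at 220 nM, within a range from 60 nM to 800 nM in this assay.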

Compound 3, half-maximal effective concentration: 1470 nM
Estimate against measurement, compound 3: 6.7-fold (0.82 log units) below; the measured number lies above the stated range.
By their numbers in this assay, from the lowest: compound 2; then compounds 3 and 1 (each within the scatter of the next).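

The position on the five-membered ring, next to the ring sulfur, is not a neutral spot: replacing chloro with ethyl here gives a 6.7-fold higher number from compound 2 to compound 3 (0.82 log units; beyond the scatter) in this assay, so more compound is needed for the same effect. Within the data shown here, the only earlier step, a 9.9-fold lower number from compound 1 to compound 2 (0.99 log units; beyond the scatter), changed the phenyl ring, so this result adds something new: the number responds to a change on the shared core as well as to one on the phenyl ring, and a swap of just one small group is enough to move it beyond the scatter. Nothing measured here explains why ethyl and chloro differ at this position.

Going by these compounds, with only chloro and ethyl at this position, it remains open whether chloro is special or whether a plain hydrogen, a methyl or a bromo would give a number close to that of compound 2. Also open, on these data alone, is how an amine or a longer chain would behave here, and whether the same swap would shift the number similarly with the 4-nitrophenyl group of compound 1 in place.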